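Replacing the imidazolyl group: from compound 3 to compound 4

This account rests on a few compounds, and the source may have more. Where it says the series, first, only, none or still open, it means among the compounds named here.

Compounds measured so far in an assay on CHO cells for antagonist activity at transient receptor potential cation channel subfamily V member 1 (Homo sapiens), read by FLIPR; a higher number here means a weaker inhibitor, a lower number a stronger inhibitor:
- compound 1, `CC(C(=O)NCc1ccc(C(F)(F)F)nc1-c1ccc(C(C)(C)C)cc1)c1ccc(NS(C)(=O)=O)c(F)c1`, gives 0.5 nM
- compound 2, `CC(C(=O)NCc1ccc(C(F)(F)F)nc1-c1ccc(F)c(Cl)c1)c1ccc(NS(C)(=O)=O)c(F)c1`, gives 0.2 nM
- compound 3, `CC(C(=O)NCc1ccc(C(F)(F)F)nc1-n1ccnc1)c1ccc(NS(C)(=O)=O)c(F)c1`, gives 36.1 nM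

Compound 3 stands at the highest number of the three, that is, it is the weakest inhibitor shown: it lies a 72-fold higher number from compound 1 to compound 3 (1.86 log units; beyond the scatter) and a 180-fold higher number from compound 2 to compound 3 (2.26 log units; beyond the scatter). Both of those steps exchanged a six-membered aromatic ring of carbon only, attached directly to the shared core, for a 1H-imidazol-1-yl group, and both cost a great deal of potency. The smaller exchange between the two carbon rings themselves, a 2.5-fold lower number from compound 1 to compound 2 (0.40 log units; beyond the scatter), mattered far less.

Compound 4, `CC(C(=O)NCc1ccc(C(F)(F)F)nc1C#Cc1ccccc1)c1ccc(NS(C)(=O)=O)c(F)c1`, is not yet measured. It differs from compound 3 in one place: 2-phenylethynyl in place of 1H-imidazol-1-yl on an aromatic carbon. The group that enters again brings a six-membered aromatic ring of carbon only, now held on a triple bond, and removes the two ring nitrogens of the imidazolyl group. The two large steps above bear on this change, and a large step in the opposite direction is therefore expected, although the triple bond has no precedent among the compounds shown, so the expected step of an 18-fold lower number from compound 3 to compound 4 (1.26 log units; beyond the scatter) is set somewhat short of a full return to the level of compound 1. In this assay compound 4 is estimated at 2 nM, with a range from 0.3 nM to 15 nM.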

Compound 4, inhibition constant: 0.8 nM
Compound 4: the middle estimate sits 2.5-fold (0.40 log units) above what was measured, within the range that was stated.
By their numbers in this assay, from the lowest: compound 2; then compounds 1 and 4 (each within the scatter of the next); then compound 3.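

In this assay, on this aromatic carbon next to the ring nitrogen, 2-phenylethynyl recovers the potency lost with 1H-imidazol-1-yl, with a 45-fold lower number from compound 3 to compound 4 (1.65 log units; beyond the scatter), so the six-membered carbon ring need not be attached directly to the shared core and can instead be held on a triple bond. Compared with the 4-(tert-butyl)phenyl group, 2-phenylethynyl cannot be told apart from it in this assay, with a 1.6-fold higher number from compound 1 to compound 4 (0.20 log units; within the scatter), so at this level of precision the triple bond brings neither a measurable gain nor a measurable loss here. The 3-chloro-4-fluorophenyl group still keeps a real edge, with a 4.0-fold higher number from compound 2 to compound 4 (0.60 log units; beyond the scatter), which leaves compound 2 the strongest inhibitor of the four.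

No measurement of any other kind is available to explain these differences in potency. As far as these compounds go, the change from compound 3 to compound 4 swaps the ring and its nitrogens and adds the triple bond all at once, so the contribution of each remains open, and a pyridine ring on the triple bond, a plain alkyl chain ending in a triple bond, or a piperidine ring on this carbon would help to separate them.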